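This account rests on a few compounds, and the source may have more. Where it says the series, first, only, none or still open, it means among the compounds named here.

Measured compounds:
Compound 1, `O=S(=O)(O)c1ccc(F)c2ncc(I)cc12`, gives 2300 nM in an assay for inhibition of methylcytosine dioxygenase TET2 (Homo sapiens), read by mass spectrometry, with stated times of 30 min and 1 h; on this read-out higher numbers stand for weaker inhibition and lower numbers for stronger inhibition.
Compound 2, `COS(=O)(=O)c1ccc(F)c2ncc(I)cc12`, gives > 200000 nM in this assay, which is a limit of the assay and not a number.
Compound 3, `CC(C)OS(=O)(=O)c1ccc(F)c2ncc(I)cc12`, gives > 200000 nM in this assay, again a limit of the assay.

Compound 3 therefore stands at the limit of this assay, with no number of its own; it sits at the limit of > 200000 nM in this assay, at which 2 of the 3 values shown sit. The two steps that lead there are both large: an at least 86-fold higher number from compound 1 to compound 2 (1.93 log units; beyond the scatter) and an at least 86-fold higher number from compound 1 to compound 3 (1.93 log units; beyond the scatter). The step between the two esters, a step that the two limits leave unreadable from compound 2 to compound 3, cannot be read, since both ends are limits.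

Compound 4, `CCCCCOS(=O)(=O)c1ccc(F)c2ncc(I)cc12`, differs from compound 3 in one place: pentyl in place of isopropyl on an oxygen. This is a third ester on the same oxygen. The two measured steps that bear on it both show that replacing the hydrogen on that oxygen with an alkyl group drives the number past the limit, and nothing measured shows the chain length making a difference. Compound 4 is thus expected to remain at the limit, with an expected step that the limit leaves unreadable from compound 3 to compound 4. Compound 4 is estimated at 250000 nM, with a range from 100000 nM to 1000000 nM.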

Compound 4, half-maximal inhibitory concentration: > 200000 nM
Compound 4 gave a limit, no number; the forecaster's own chance of this, stated with the estimate: 85%; the middle value does not contradict the limit.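

In this assay, pentyl on the oxygen gives an at least 86-fold higher number from compound 1 to compound 4 (1.93 log units; beyond the scatter), so the loss seen with methyl and isopropyl holds for a longer chain as well. The steps among the three esters cannot be read, as both ends of each are limits, and any difference made by chain length on that oxygen therefore stays out of sight. With compound 4 added, the esters stand together at one limit of the assay, which is not a number: the limit of > 200000 nM in this assay, at which 3 of the 4 values shown sit.

From the compounds shown here alone, it remains open whether the free hydroxyl on the sulfonyl sulfur can be replaced at all with a readable number kept, for example by an amine on that sulfur in a sulfonamide, or by a carboxylic acid in place of the whole sulfonic acid. Also open, going by these compounds, is how other changes to the core would act on compound 1, which gives 2300 nM.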